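This account rests on a few compounds, and the source may have more. Where it says the series, first, only, none or still open, it means among the compounds named here.

Measured compounds:
compound 1 `CC(C)Oc1cc(=O)oc2cc(OCc3cccc(Cl)c3)ccc12` gives 24500 nM
compound 2 `CNC(=O)COc1cc(=O)oc2cc(OCc3cccc(Cl)c3)ccc12` gives 33.9 nM
compound 3 `CN(C)C(=O)COc1cc(=O)oc2cc(OCc3cccc(Cl)c3)ccc12` gives 501 nM

In an assay on isolated protein (strain Sprague-Dawley) for inhibition of Amine oxidase [flavin-containing] B (Rattus norvegicus), read by spectrophotometry, with a stated time of 5 min (on this read-out lower numbers stand for stronger inhibition and higher numbers for weaker inhibition), compound 3 stands second highest of the three, below compound 2 and well above compound 1. Compound 4 `O=C(COc1cc(=O)oc2cc(OCc3cccc(Cl)c3)ccc12)N1CCCCC1` differs from it by piperidin-1-yl in place of dimethylamino on a carbonyl carbon. Among the measured compounds shown here, no measured step changes the amine of the amide in this way; the nearest is a 15-fold higher number from compound 2 to compound 3 (1.17 log units; beyond the scatter), where substitution on the amide-type nitrogen raised the number. The other steps, a 720-fold lower number from compound 1 to compound 2 (2.86 log units; beyond the scatter) and a 49-fold lower number from compound 1 to compound 3 (1.69 log units; beyond the scatter), concern the side chain as a whole. On this basis compound 4 is expected to land near compound 3 or somewhat higher, with the step of a 1.6-fold higher number from compound 3 to compound 4 (0.20 log units; within the scatter) expected. The estimate for compound 4 is 800 nM, between 200 nM and 3000 nM.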

Compound 4, half-maximal inhibitory concentration: 38900 nM
Estimate against measurement, compound 4: 49-fold (1.69 log units) below; measured number above the stated range.
By their numbers in this assay, from the lowest: compound 2; then compound 3; then compounds 1 and 4 (each within the scatter of the next).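

In this assay, the amine on the carbonyl carbon proves decisive: a 78-fold higher number from compound 3 to compound 4 (1.89 log units; beyond the scatter) and a 1100-fold higher number from compound 2 to compound 4 (3.06 log units; beyond the scatter) show that piperidin-1-yl removes nearly all the advantage seen with the smaller amides. With a 1.6-fold higher number from compound 1 to compound 4 (0.20 log units; within the scatter), the carbonyl-bearing side chain alone therefore does not secure a low number. No measurement given here accounts for this jump. The compounds shown leave open whether the ring itself or the number of carbons on the amide nitrogen matters. Diethylamino or pyrrolidin-1-yl on the same carbonyl carbon would bear on that question.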